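Working notes: thiophen-2-yl in place of 3-methylfuran-2-yl

The compounds below may be only part of what the source reports. "The series", "measured", "known", "first", "only" and "open" are said of these compounds alone.

The series shares one core and is varied only at a saturated ring carbon. Compound 1 `N#CC1=C(N)N(c2ccc(S(N)(=O)=O)cc2)C2=C(C(=O)CCC2)C1c1ccccc1` carries phenyl there, compound 2 `COc1ccc(C2C(C#N)=C(N)N(c3ccc(S(N)(=O)=O)cc3)C3=C2C(=O)CCC3)cc1` 4-methoxyphenyl, compound 3 `Cc1ccoc1C1C(C#N)=C(N)N(c2ccc(S(N)(=O)=O)cc2)C2=C1C(=O)CCC2` 3-methylfuran-2-yl. In a functional assay on Ehrlich cells (Mus musculus) for antiproliferative activity, read by trypan blue exclusion, with a stated time of 2 h (on this read-out higher numbers stand for weaker inhibition and lower numbers for stronger inhibition), compound 2 gives 25 ug/mL. For compound 1 the read-out in this assay is a limit, > 100 ug/mL. For compound 3 it is likewise a limit, > 100 ug/mL. Compound 3 thus sits at the limit of > 100 ug/mL in this assay, at which 2 of the 3 values shown sit, and is not separated from compound 1, the step being a step that the two limits leave unreadable from compound 1 to compound 3. Against compound 2 the step is readable, an at least 4.0-fold higher number from compound 2 to compound 3 (0.60 log units; beyond the scatter), and the methoxy step itself is an at least 4.0-fold lower number from compound 1 to compound 2 (0.60 log units; beyond the scatter).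

Compound 4 `N#CC1=C(N)N(c2ccc(S(N)(=O)=O)cc2)C2=C(C(=O)CCC2)C1c1cccs1` differs from compound 3 in one place: thiophen-2-yl in place of 3-methylfuran-2-yl on a saturated ring carbon. Going by the values given here, no measured step exchanges one five-membered heteroaryl for another; the only steps touching this carbon are those into compound 3, and both leave it at the limit. The one five-membered heteroaryl measured gave no number in this assay, so compound 4 is expected to remain near that limit, with an expected step that the limit leaves unreadable from compound 3 to compound 4 that stays within the scatter. The estimate for compound 4 in this assay is 150 ug/mL, with a range from 50 ug/mL to 400 ug/mL.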

Compound 4, half-maximal inhibitory concentration: 5 ug/mL
Estimate against measurement, compound 4: 30-fold (1.48 log units) above; measured number below the stated range.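

In this assay, the thiophen-2-yl group shows that a five-membered aromatic ring with 1 hetero atom can give a readable number on this saturated ring carbon, and the exchange for 3-methylfuran-2-yl is an at least 20-fold lower number from compound 3 to compound 4 (1.30 log units; beyond the scatter). Going by these compounds alone, the position therefore responds strongly to the identity of the five-membered ring, and the 4-methoxyphenyl group no longer gives the only readable number, with a 5.0-fold lower number from compound 2 to compound 4 (0.70 log units; beyond the scatter) and, against the unsubstituted phenyl group, an at least 20-fold lower number from compound 1 to compound 4 (1.30 log units; beyond the scatter). The step between compound 1 and compound 3 still cannot be read, and each of these two compounds has a limit rather than a number, which also makes the steps from them to compound 4 lower bounds: the limit of > 100 ug/mL in this assay, at which 2 of the 4 values shown sit.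

The exchange of 3-methylfuran-2-yl for thiophen-2-yl replaces the ring oxygen with sulfur and removes the methyl group in a single step, so the data do not assign the gain to either change. Furan-2-yl without the methyl group and 3-methylthiophen-2-yl would separate the two, while thiophen-3-yl would test whether the point of attachment on the thiophene matters.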